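Notes on compound 3: propylamino at the carbonyl

This account rests on a few compounds, and the source may have more. Where it says the series, first, only, none or still open, it means among the compounds named here.

Values in a functional assay on A2780 cells (Homo sapiens) for antiproliferative activity, read by fluorescence, with a stated time of 72 h; a lower number here means a stronger inhibitor, a higher number a weaker inhibitor:
- compound 1 `CN1CCC(C(=O)N2Cc3c(NC(=O)c4cccs4)n[nH]c3C2(C)C)CC1` gives 30 nM
- compound 2 `CN1CCC(C(=O)N2Cc3c(NC(=O)c4ccc(C(F)(F)F)cc4)n[nH]c3C2(C)C)CC1` gives 60 nM

Among the compounds with values here, the only measured step is a 2.0-fold higher number from compound 1 to compound 2 (0.30 log units; within the scatter). Within the data shown here, compound 2 therefore stands level with the sole other measured compound, within the scatter.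

Compound 3 `CCCNC(=O)Nc1n[nH]c2c1CN(C(=O)C1CCN(C)CC1)C2(C)C` keeps the shared core and has propylamino in place of 4-(trifluoromethyl)phenyl on a carbonyl carbon. The measured step exchanges one ring for another, whereas this change removes the ring, so it bears only loosely. Among the measured compounds shown here, no measured compound lacks a ring at this place. Starting from compound 2 at 60 nM, a modest move to a higher number in this assay is expected, with wide uncertainty. The expected step is a 2.2-fold higher number from compound 2 to compound 3 (0.34 log units; beyond the scatter). For compound 3 the estimated value is 130 nM, with an expected range of 35 nM to 500 nM.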

Compound 3, half-maximal inhibitory concentration: 650 nM
Estimate against measurement, compound 3: 5.0-fold (0.70 log units) below, outside the stated range (above it).
By their numbers in this assay, from the lowest: compounds 1 and 2 (each within the scatter of the next); then compound 3.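

In this assay, within the data shown here, propylamino on the carbonyl carbon gives the first step at this place that lies beyond the scatter, an 11-fold higher number from compound 2 to compound 3 (1.03 log units; beyond the scatter), and the comparison with the thiophene amide gives a 22-fold higher number from compound 1 to compound 3 (1.34 log units; beyond the scatter). Exchanging one ring for another left compound 1 and compound 2 within the scatter of each other, whereas compound 3, the only one shown with no ring here, stands well apart from both, so this place is not indifferent to every replacement. The change removes the aromatic ring, shortens the group by heavy-atom count and adds a hydrogen-bond donor all at once, and nothing on hand accounts for the loss.

Which of these differences matters remains open. A phenylamino group would keep the aromatic ring together with the added nitrogen, and a cyclohexyl group would keep a ring without that nitrogen, so the two would help separate them.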